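The source may hold more compounds than are shown below. What is called first, only, known or untested is meant among the compounds shown, and "the series" means these compounds.

Measured so far in a functional assay on BGC-823 cells (Homo sapiens) for cytotoxicity, read by MTT assay; on this read-out lower numbers stand for stronger inhibition and higher numbers for weaker inhibition:

compound 1 `Cc1ccc(Nc2nc(C)c(C(=O)/C=C/c3ccccc3)s2)cc1`: > 25000 nM, a limit of the assay and not a number.
compound 2 `COc1cc(/C=C/C(=O)c2sc(Nc3cccc(C)c3)nc2C)cc(OC)c1OC`: 17200 nM.
compound 3 `Cc1nc(Nc2ccccc2)sc1C(=O)/C=C/c1ccc(Cl)cc1`: > 25000 nM, again a limit and not a number.

Among the measured compounds shown here, compound 2 thus holds the only number in the set; the two other values are limits. The weak picture rests on (the limit of > 25000 nM in this assay, at which 2 of the 3 values shown sit).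

Compound 4 `COc1cc(/C=C/C(=O)c2sc(Nc3ccc(F)c(Cl)c3)nc2C)cc(OC)c1OC` differs from compound 2 in one place: 3-chloro-4-fluorophenyl in place of 3-methylphenyl on a nitrogen on an aromatic ring. No change of this kind has yet been measured in the series, so no size or direction of step can be read from what is shown. The expected step from compound 2 to compound 4 is a 1.1-fold lower number from compound 2 to compound 4 (0.06 log units; within the scatter), that is none beyond the usual scatter. For compound 4 in this assay the estimate is 15000 nM, with a range from 5000 nM to 50000 nM.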

Compound 4, half-maximal inhibitory concentration: 9700 nM
Beside the measured number, compound 4's estimate is 1.5-fold (0.19 log units) above it, within the range that was stated.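

In this assay, the first step read at this position is a 1.8-fold lower number from compound 2 to compound 4 (0.25 log units; within the scatter). On this evidence, 3-chloro-4-fluorophenyl and 3-methylphenyl on this nitrogen cannot be told apart, so this change does not separate compound 2 from compound 4. Both still give numbers rather than limits, while the weak end of the set remains: the limit of > 25000 nM in this assay, at which 2 of the 4 values shown sit.

Still open, from the compounds shown here alone, is whether a 4-fluorophenyl, a 3-chlorophenyl or a pyridyl group on this nitrogen would give a step beyond the scatter. Also open, going by these compounds, is what a carboxylic acid or an aminoalkyl chain would do there.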